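Replacing the 4-fluorobenzyl on the ring nitrogen of compound 1

This account rests on a few compounds, and the source may have more. Where it says the series, first, only, none or still open, it means among the compounds named here.

Measured so far:
compound 1 `Fc1ccc(CN2CCC(NCCSC(c3ccc(F)cc3)c3ccc(F)cc3)CC2)cc1` gives 13.3 nM
compound 2 `Fc1ccc(C(SCCNC2CCN(Cc3ccc(C(F)(F)F)cc3)CC2)c2ccc(F)cc2)cc1` gives 186 nM
compound 3 `[O-][S+](CCNC1CCN(CC(O)Cc2ccccc2)CC1)C(c1ccc(F)cc1)c1ccc(F)cc1` gives 351 nM

In an assay on membranes from Cortex for displacement of a labelled ligand from Sigma non-opioid intracellular receptor 1 (Cavia porcellus), read by scintillation counting, with a stated time of 120 min (a lower number here means a stronger inhibitor, a higher number a weaker inhibitor), compound 1 gives the lowest number of the three; compound 2 and compound 3 both give higher numbers, and compound 3 differs from compound 1 in more than one place, so its value shows only that it sits well above compound 1. Among the compounds with values here, the single one-place step, a 14-fold higher number from compound 1 to compound 2 (1.15 log units; beyond the scatter), keeps the 4-fluorobenzyl ring and changes only its substituent.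

Within the data shown here, compound 4 `CC(C)(C)C(=O)N1CCC(NCCSC(c2ccc(F)cc2)c2ccc(F)cc2)CC1` has not been measured. (tert-butyl)carbonyl in place of 4-fluorobenzyl on an amine nitrogen in a ring No measured step touches the amine nitrogen in the ring, so there is no direct precedent. Since a smaller change on the same group already cost a large step, a large upward step is expected, a 60-fold higher number from compound 1 to compound 4 (1.78 log units; beyond the scatter). Compound 4 is expected to give about 800 nM, within 150 nM to 4000 nM.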

Compound 4, inhibition constant: 163 nM
For compound 4 the middle estimate is 4.9-fold (0.69 log units) above the measured one; low and high end bracket the measured number.
By their numbers in this assay, from the lowest: compound 1; then compounds 4, 2 and 3 (each within the scatter of the next, the first and the last beyond it).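

In this assay, a 12-fold higher number from compound 1 to compound 4 (1.09 log units; beyond the scatter) shows that the 4-fluorobenzyl on the amine nitrogen in the ring matters beyond its substituent: a group with no ring, (tert-butyl)carbonyl, also lands well above compound 1. With a 1.1-fold lower number from compound 2 to compound 4 (0.06 log units; within the scatter), (tert-butyl)carbonyl and 4-(trifluoromethyl)benzyl cannot be told apart at this position, although they share little in structure. No accompanying data bear on the reason for either step.

Open, from the compounds shown here alone, is how an unsubstituted benzyl or a smaller acyl group such as acetyl would compare on this nitrogen.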